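This account rests on a few compounds, and the source may have more. Where it says the series, first, only, none or still open, it means among the compounds named here.

Measured so far in a functional assay on brain (Rattus norvegicus, strain Wistar) for inhibition; on this read-out higher numbers stand for weaker inhibition and lower numbers for stronger inhibition:

- compound 1 `COc1ccc(-c2c(C)[nH]c(=O)n2C)cc1` gives 147000 nM
- compound 2 `Cc1[nH]c(=O)n(C)c1-c1ccc(C(C)(C)C)cc1` gives 8400 nM
- compound 3 `CCCCCOc1ccc(-c2c(C)[nH]c(=O)n2C)cc1` gives 4500 nM

Compound 3 shares the low end of these numbers with compound 2, the two being separated by a 1.9-fold lower number from compound 2 to compound 3 (0.27 log units; within the scatter). Compound 4 `CCCCCCCOc1ccc(-c2c(C)[nH]c(=O)n2C)cc1` differs from compound 3 by ethyl in place of hydrogen on a saturated chain carbon, five bonds along the chain from an oxygen on an aromatic ring. Among the measured compounds shown here, the closest precedent is a 33-fold lower number from compound 1 to compound 3 (1.51 log units; beyond the scatter), a lengthening of the same chain that is large and beyond the scatter. The steps of an 18-fold lower number from compound 1 to compound 2 (1.24 log units; beyond the scatter) and a 1.9-fold lower number from compound 2 to compound 3 (0.27 log units; within the scatter) replace the whole group and bear on this change less directly. For the measured compounds named here, a smaller step in the same direction is therefore expected in this assay, although no measured compound shows whether the trend holds beyond pentyloxy. The expected change is a 3.0-fold lower number from compound 3 to compound 4 (0.48 log units; beyond the scatter). Compound 4 is estimated at 1500 nM, with an expected range of 400 nM to 5500 nM.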

Compound 4, half-maximal inhibitory concentration: 5700 nM
For compound 4 the middle estimate is 3.8-fold (0.58 log units) below the measured one, and the stated range ends below it.
By their numbers in this assay, from the lowest: compounds 3, 4 and 2 (each within the scatter of the next); then compound 1.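

In this assay, adding ethyl to the pentyloxy chain gives a 1.3-fold higher number from compound 3 to compound 4 (0.10 log units; within the scatter), so the lengthening at this place brings no step beyond the scatter. The full lengthening from the methoxy compound still stands at a 26-fold lower number from compound 1 to compound 4 (1.41 log units; beyond the scatter), which means the large step from methoxy is kept but not extended by the longer chain. No evidence at hand accounts for this levelling. Going by these compounds, whether a still longer chain would keep the number level remains open, as does the effect of an amine or a carboxylic acid carried on this chain.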